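The compounds below may be only part of what the source reports. "The series", "measured", "known", "first", "only" and "open" are said of these compounds alone.

Compound 1 `Cc1nc(C)c([C@H](OC(C)(C)C)C(=O)O)c(N2CCC(C)(C)CC2)c1-c1ccc(OCCc2ccc(F)cc2F)cc1` gives 1.08 h in an ADME assay on microsomes from liver (Homo sapiens) for metabolic stability, read by LC-MS, tested at 0.5 uM; a higher number here means that the compound lasts longer, a lower number that the compound disappears faster.
Compound 2 `Cc1nc(C)c([C@H](OC(C)(C)C)C(=O)O)c(N2CCC(C)(C)CC2)c1-c1ccc(OCCc2cc(F)c(F)cc2F)cc1` gives > 2 h, a limit of this assay.
Compound 3 `Cc1nc(C)c([C@H](OC(C)(C)C)C(=O)O)c(N2CCC(C)(C)CC2)c1-c1ccc(CCCc2ccc(F)cc2)cc1` gives > 2 h, which is likewise a limit.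

Within the data shown here, compound 1 stands as the only compound with a number in this assay; the other two values are limits, as the limit of > 2 h in this assay, at which 2 of the 3 values shown sit, records. The measured steps are an at least 1.8-fold higher number from compound 1 to compound 2 (0.26 log units; that floor lies within the scatter) and an at least 1.8-fold higher number from compound 1 to compound 3 (0.26 log units; that floor lies within the scatter), both floors that lie within the scatter. The step that the two limits leave unreadable from compound 2 to compound 3 cannot be sized from the two limits.

Compound 4 `Cc1ccc(CCOc2ccc(-c3c(C)nc(C)c([C@H](OC(C)(C)C)C(=O)O)c3N3CCC(C)(C)CC3)cc2)s1` has not yet been measured in this assay. Relative to compound 1 it differs as follows: 5-methylthiophen-2-yl in place of 2,4-difluorophenyl on a saturated chain carbon, two bonds along the chain from an oxygen on an aromatic ring. Among the measured compounds shown here, no measured step swaps the 2,4-difluorophenyl ring itself for another ring; the step from compound 1 to compound 2 adds a fluoro on that ring and the step from compound 1 to compound 3 rewrites the whole tail, and neither gave a step that is readable beyond the scatter. On that basis compound 4 is expected to show a step of a 1.2-fold higher number from compound 1 to compound 4 (0.08 log units; within the scatter), a change not clearly beyond the scatter. The half-life of compound 4 in this assay is estimated at 1.3 h, within the range 0.6 h to 2.5 h.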

Compound 4, half-life: > 2 h
Compound 4 gave a limit, no number (the forecaster's own chance of this, stated with the estimate: 30%); at least 1.5-fold (0.18 log units) between middle value and limit.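

In this assay compound 4 gives a limit and not a number. This is the first change shown that replaces the ring itself on the saturated chain carbon, with 5-methylthiophen-2-yl in place of 2,4-difluorophenyl, and it gives an at least 1.8-fold higher number from compound 1 to compound 4 (0.26 log units; that floor lies within the scatter). So a five-membered aromatic ring with one sulfur can stand at this place without any sign of a shorter half-life, although the floor alone does not establish a real gain over compound 1. The steps linking compound 4 to compound 2 and compound 3 cannot be read, as each joins two limits, and the set now sits mostly at one end of the scale: the limit of > 2 h in this assay, at which 3 of the 4 values shown sit.

The compounds shown leave open how far compound 2, compound 3 and compound 4 actually lie from compound 1, and whether these three tails differ from one another at all. They also leave open how a thiophen-2-yl ring without the methyl, or a pyridin-2-yl ring, would read at this same place on the chain.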